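The source may report more compounds than this note shows. Statements on the series, on what has been measured and on what is new or still open speak of the compounds shown alone.

Compound 1 `COCCCCCCCCCCCCCCC/C=C1\CC(CO)(COC(=O)C(C)(C)C)OC1=O` gives 1.75 ug/mL in a functional assay on SK-MEL-5 cells (Homo sapiens) for antiproliferative activity; on this read-out lower numbers stand for stronger inhibition of growth and higher numbers for weaker inhibition of growth. Compound 2 `CCCCCOCCCCCCC/C=C1\CC(CO)(COC(=O)C(C)(C)C)OC1=O` gives 2.99 ug/mL in this assay, and compound 3 `CC(C)(C)C(=O)OCCCCCCCCCCCCCCC/C=C1\CC(CO)(COC(=O)C(C)(C)C)OC1=O` gives 3.46 ug/mL. The three numbers all lie within the scatter of one another: a 1.7-fold higher number from compound 1 to compound 2 (0.23 log units; within the scatter) and a 2.0-fold higher number from compound 1 to compound 3 (0.30 log units; within the scatter), while the values of compound 2 and compound 3 are close to each other. Compound 4 `CC(C)(C)C(=O)OCC1(CO)C/C(=C\CCCCCCCCCCCCCCC=O)C(=O)O1` differs from compound 3 by formyl in place of (((tert-butyl)carbonyl)oxy)methyl on a saturated chain carbon, ten or more bonds along the chain from a double-bonded chain carbon. Neither measured step, each a change of the chain, moved the number beyond the scatter, so no step beyond the scatter is expected here either. Because a 2.0-fold higher number from compound 1 to compound 3 (0.30 log units; within the scatter) stayed within the scatter, compound 4 is expected near 3.2 ug/mL, with a range from 1.3 ug/mL to 8 ug/mL, an expected step of a 1.1-fold lower number from compound 3 to compound 4 (0.03 log units; within the scatter).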

Compound 4, concentration for 50% growth inhibition: > 10 ug/mL
Compound 4 was reported as a limit (the forecaster's own chance of this, stated with the estimate: 5%); middle value at least 3.1-fold (0.49 log units) from the limit.
By their numbers in this assay, from the lowest: compounds 1, 2 and 3 (each within the scatter of the next). At a limit, above all of these: compound 4.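

Compound 4 gives > 10 ug/mL in this assay, which is a limit and not a number: the limit of > 10 ug/mL in this assay, at which 1 of the 4 values shown sits.

Formyl in place of (((tert-butyl)carbonyl)oxy)methyl on a saturated chain carbon gives the first step beyond the scatter, with an at least 2.8-fold higher number from compound 3 to compound 4 (0.46 log units; beyond the scatter). The comparisons with the other two chains also lie beyond the scatter, with an at least 3.3-fold higher number from compound 2 to compound 4 (0.52 log units; beyond the scatter) and an at least 5.7-fold higher number from compound 1 to compound 4 (0.75 log units; beyond the scatter), whereas the steps from compound 1 to compound 2 and to compound 3 stayed within it.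

On these data alone, the full size of these steps remains open. Also open, as far as these compounds go, is whether this is specific to formyl, or whether a carboxylic acid, a hydroxyl or an amine in its place would give the same result.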